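The source may hold more compounds than are shown below. What is called first, only, known or untested is meant among the compounds shown, and "the series" means these compounds.

Measured in an ADME assay on L1210/0 cells (Mus musculus) for cytotoxicity, with a stated time of 48 h; a lower number here means a stronger inhibitor, a higher number a weaker inhibitor:
- compound 1 `N#CSc1cn([C@H]2C[C@H](O)[C@@H](CO)O2)c(=O)[nH]c1=O`: 78900 nM
- compound 2 `C=Cc1cn([C@H]2C[C@H](O)[C@@H](CO)O2)c(=O)[nH]c1=O`: 14200 nM
- compound 3 `N#Cc1cn([C@H]2C[C@H](O)[C@@H](CO)O2)c(=O)[nH]c1=O`: > 200000 nM

Compound 3 sits at the limit of > 200000 nM in this assay, at which 1 of the 3 values shown sits, so it has a limit and not a number. Compound 4 `C[S+]([O-])c1cn([C@H]2C[C@H](O)[C@@H](CO)O2)c(=O)[nH]c1=O` differs from it on one aromatic carbon: a group of 3 heavy atoms (1 carbon, 1 oxygen, 1 sulfur; no ring) in place of a group of 2 heavy atoms (1 carbon, 1 nitrogen; no ring), on an aromatic carbon. Two measured steps end on the cyano group, an at least 2.5-fold higher number from compound 1 to compound 3 (0.40 log units; beyond the scatter) and an at least 14-fold higher number from compound 2 to compound 3 (1.14 log units; beyond the scatter). Read backwards, both say that replacing cyano gave a lower number. Neither step involves the group entering here, so their sizes are only a rough guide. The closest guide is compound 1, which also carries sulfur on that carbon and gives 78900 nM. A modest step to a lower number is therefore expected in this assay, though another limit is quite possible. The expected step is an at least 2.2-fold lower number from compound 3 to compound 4 (0.34 log units; beyond the scatter). Compound 4 is estimated at 90000 nM, with an expected range of 25000 nM to 200000 nM.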

Compound 4, half-maximal inhibitory concentration: > 200000 nM
Compound 4: a limit, no number; the forecaster's own chance of this, stated with the estimate: 40%; middle value at least 2.2-fold (0.34 log units) away from the limit.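

In this assay, compound 4 gives a limit and not a number, so the step involving compound 3 cannot be read. The steps that can be read are an at least 2.5-fold higher number from compound 1 to compound 4 (0.40 log units; beyond the scatter) and an at least 14-fold higher number from compound 2 to compound 4 (1.14 log units; beyond the scatter), so sulfur on this aromatic carbon does not by itself give a measurable value. Compound 3 and compound 4 now share the same limit: the limit of > 200000 nM in this assay, at which 2 of the 4 values shown sit.

Going by these compounds, how far apart compound 3 and compound 4 really lie stays open. So does whether an amine or a longer chain on this carbon would give a lower number than the vinyl group.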